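Lengthening the Chain on the Amide Nitrogen

A few compounds are considered here, and "the series" means these few. Any claim that something is new, unique, unknown or untested is made for them only; others in the source may bear on it.

In an assay on HEK293 cells for inhibition of transient receptor potential cation channel subfamily M member 8 (Homo sapiens), read by FLIPR and calcium flux (a lower number here means a stronger inhibitor, a higher number a weaker inhibitor), compound 3, `CN(C(=O)c1ccccc1OCc1ccccc1)[C@@H]1CCC[C@H](N)C1`, is the only one of the three measured compounds to give an actual number: it gives 3670 nM. Compound 1, `CN(C(=O)c1ccccc1OCc1ccccc1)[C@@H]1CCNC1`, reaches only the limit > 10000 nM in this assay. Compound 2, `NC1CCN(C(=O)c2ccccc2OCc2ccccc2)C1`, likewise reaches only the limit > 10000 nM. Most of the values shown therefore rest on (the limit of > 10000 nM in this assay, at which 2 of the 3 values shown sit). Within the data shown here, the single readable step runs an at least 2.7-fold lower number from compound 1 to compound 3 (0.43 log units; beyond the scatter), while the other step is a step that the two limits leave unreadable from compound 1 to compound 2.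

Compound 4, `CCCCN(C(=O)c1ccccc1OCc1ccccc1)[C@@H]1CCC[C@H](N)C1`, differs from compound 3 by propyl in place of hydrogen on a saturated chain carbon bound to an amide-type nitrogen. Among the measured compounds shown here, none of the measured steps alters this small chain: the step from compound 1 to compound 3 changed the ring attached to the nitrogen and shows that changes around this nitrogen can move the number, but it gives no direction for a longer chain. For the measured compounds named here, with no step bearing on the change, the expected step is a 1.0-fold lower number from compound 3 to compound 4 (0.02 log units; within the scatter), within the scatter. Compound 4 is thus estimated at 3500 nM, with a range from 800 nM to 15000 nM.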

Compound 4, antagonist equilibrium constant: 1560 nM
The estimate for compound 4 lay 2.2-fold (0.35 log units) above the measured number; measured number inside the range.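

Among these compounds, the earlier compounds showed only that changing the ring on the amide-type nitrogen could move the number in this assay. The change from methyl to butyl now gives a 2.4-fold lower number from compound 3 to compound 4 (0.37 log units; beyond the scatter), so the chain on that same nitrogen can move the number too. The step is modest and rests on a single pair of compounds, but it shows that, at least on this core, the longer chain lowers the number rather than raising it.

On these data alone, whether the number keeps falling with a longer chain such as hexyl, or whether a chain ending in an amine or a carboxylic acid behaves the same way, remains open. It is also open whether butyl would do the same on compound 1, and the values give little footing for that question: the limit of > 10000 nM in this assay, at which 2 of the 4 values shown sit.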